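Swapping one thiazole for another on the benzamide arm

This account rests on a few compounds, and the source may have more. Where it says the series, first, only, none or still open, it means among the compounds named here.

Measured so far:
- Compound 1, `O=C(COc1ccc2c(=O)ccoc2c1)Nc1cccc(NC(=O)c2ccccc2)c1`, gives 16 nM in an assay on isolated protein for inhibition of Rho-associated protein kinase 2 (Homo sapiens), read by scintillation counting, radiometric assay and 33P incorporation, with a stated time of 40 min, in the presence of a further agent that is not named here; a lower number here means a stronger inhibitor, a higher number a weaker inhibitor.
- Compound 2, `Cc1nc(C(=O)Nc2cccc(NC(=O)COc3ccc4c(=O)ccoc4c3)c2)cs1`, gives 33 nM in this assay.

Compound 2 holds the higher of the two numbers, meaning it is the weaker inhibitor of the pair: the change a 2.1-fold higher number from compound 1 to compound 2 (0.31 log units; beyond the scatter) came with a phenyl group replaced by a 2-methyl-1,3-thiazol-4-yl group on the carbonyl carbon.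

Among the compounds with values here, compound 3, `O=C(COc1ccc2c(=O)ccoc2c1)Nc1cccc(NC(=O)c2cnc(C(F)(F)F)s2)c1`, keeps the shared core and changes only that ring: 2-(trifluoromethyl)-1,3-thiazol-5-yl in place of 2-methyl-1,3-thiazol-4-yl on a carbonyl carbon. Within the data shown here, the only step measured so far that bears on this position is the one from compound 1 to compound 2, which was modest and stayed close to the scatter. A five-membered ring with two hetero atoms stays in place, so no large move in this assay is expected in either direction, and the number is estimated near that of compound 2. The expected step is a 1.2-fold higher number from compound 2 to compound 3 (0.08 log units; within the scatter). Compound 3 is therefore estimated at 40 nM, with a range from 15 nM to 110 nM.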

Compound 3, half-maximal inhibitory concentration: 10 nM
The estimate for compound 3 lay 4.0-fold (0.60 log units) above the measured number; the whole stated range lies above it.
By their numbers in this assay, from the lowest: compounds 3 and 1 (each within the scatter of the next); then compound 2.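

Thiazoles on this carbonyl carbon are not interchangeable: replacing 2-methyl-1,3-thiazol-4-yl with 2-(trifluoromethyl)-1,3-thiazol-5-yl gives a 3.3-fold lower number from compound 2 to compound 3 (0.52 log units; beyond the scatter) in this assay. The loss seen with the first thiazole therefore does not extend to every thiazole, since the new ring set against the original phenyl group gives a 1.6-fold lower number from compound 1 to compound 3 (0.20 log units; within the scatter) and the two compounds cannot be told apart. This swap changes both the group on the ring and the ring's point of attachment, and nothing available here explains the result.

Which of those two changes matters remains open, and a 2-methyl-1,3-thiazol-5-yl group would separate them. From the compounds shown here alone, it is also open how a thiazole carrying an amine or a carboxylic acid in place of trifluoromethyl would behave at this position.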